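Varying the amine substituent on a shared core

This account rests on a few compounds, and the source may have more. Where it says the series, first, only, none or still open, it means among the compounds named here.

Compound 1 `CC[C@H](C)[C@@H](NCC(=O)NNC(=O)COc1ccc(-c2nc3ccccc3s2)cc1OC)C(=O)O` gives 3990 nM in a functional assay on HepG2 cells (Homo sapiens) for inhibition, read by MTT assay, with a stated time of 3 days (a lower number here means a stronger inhibitor, a higher number a weaker inhibitor), the highest of the three numbers measured. Compound 2 `COc1cc(-c2nc3ccccc3s2)ccc1OCC(=O)NNC(=O)CN[C@@H](CCSC)C(=O)O` gives 3780 nM and compound 3 `CCOC(=O)CN(C)CC(=O)NNC(=O)COc1ccc(-c2nc3ccccc3s2)cc1OC` gives 3180 nM; the gaps to compound 1 stay inside the scatter, as does a 1.2-fold lower number from compound 2 to compound 3 (0.08 log units; within the scatter). Compound 4 `CCOC(=O)[C@H](CS(=O)(=O)O)NCC(=O)NNC(=O)COc1ccc(-c2nc3ccccc3s2)cc1OC` differs from compound 1 in one place: 1-(ethoxycarbonyl)-2-sulfoethyl in place of 1-carboxy-2-methylbutyl on an amine nitrogen. Both a 1.1-fold lower number from compound 1 to compound 2 (0.02 log units; within the scatter) and a 1.3-fold lower number from compound 1 to compound 3 (0.10 log units; within the scatter) exchanged the group on an amine nitrogen without moving the number beyond the scatter, which points to a step of no more than the scatter here, in no set direction. Compound 4 is therefore estimated at 3800 nM, within 1600 nM to 9000 nM. That estimate means an expected 1.1-fold lower number from compound 1 to compound 4 (0.02 log units; within the scatter).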

Compound 4, half-maximal inhibitory concentration: 3360 nM
Estimate against measurement, compound 4: 1.1-fold (0.05 log units) above, and the stated range covers the measured number.
By their numbers in this assay, from the lowest: compounds 3, 4, 2 and 1 (each within the scatter of the next).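

In this assay, 1-(ethoxycarbonyl)-2-sulfoethyl on the amine nitrogen brings more heavy atoms and hydrogen-bond acceptors than 1-carboxy-2-methylbutyl, yet the result is a 1.2-fold lower number from compound 1 to compound 4 (0.07 log units; within the scatter). The comparisons with the other two groups agree: a 1.1-fold lower number from compound 2 to compound 4 (0.05 log units; within the scatter) and a 1.1-fold higher number from compound 3 to compound 4 (0.02 log units; within the scatter). No supporting measurement bears on this result.

Going by these compounds, whether any group at this place can move the number beyond the scatter remains open. A benzyl group or a chain ending in a free amine would test this.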